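Returning an alkyl group to the phenyl ether of compound 3

A few compounds are considered here, and "the series" means these few. Any claim that something is new, unique, unknown or untested is made for them only; others in the source may bear on it.

Measured so far:
compound 1 `CCc1ccccc1OC1CCN(c2ccc(-n3ccnc3)nn2)CC1` gives 4 nM
compound 2 `c1cc(OC2CCN(c3ccc(-n4ccnc4)nn3)CC2)c2cc[nH]c2c1` gives 162 nM
compound 3 `N#Cc1ccccc1OC1CCN(c2ccc(-n3ccnc3)nn2)CC1` gives 236 nM

These three compounds share a core and differ only in the aryl group on the oxygen on the saturated carbon. In an assay on microsomes from liver for inhibition of acyl-CoA desaturase 1 (Rattus norvegicus) (a higher number here means a weaker inhibitor, a lower number a stronger inhibitor), compound 1 gives 4 nM and stands apart from the other two: the change of cyano in place of ethyl on an aromatic carbon gave a 59-fold higher number from compound 1 to compound 3 (1.77 log units; beyond the scatter), and the change to 1H-indol-4-yl gave a 41-fold higher number from compound 1 to compound 2 (1.61 log units; beyond the scatter). Compound 3, with 236 nM, has the highest number of the three, though the nearest step is only a 1.5-fold higher number from compound 2 to compound 3 (0.16 log units; within the scatter), which is within the scatter.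

Compound 4 `Cc1ccc(OC2CCN(c3ccc(-n4ccnc4)nn3)CC2)cc1` has not yet been measured. It differs from compound 3 by 4-methylphenyl in place of 2-cyanophenyl on an oxygen on a saturated carbon. Going by the values given here, the step that bears most on it is the one from compound 1 to compound 3, where cyano in place of ethyl gave a 59-fold higher number from compound 1 to compound 3 (1.77 log units; beyond the scatter). Compound 4 reverses the cyano for an alkyl group, though the 4-methylphenyl is not the same group as the 2-ethylphenyl of compound 1, so only part of that step is expected to be recovered. Compound 4 is therefore expected to give a lower number, estimated at 40 nM, with a range from 8 nM to 200 nM, which corresponds to an expected step of a 5.9-fold lower number from compound 3 to compound 4 (0.77 log units; beyond the scatter).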

Compound 4, half-maximal inhibitory concentration: 527 nM
Compound 4: the middle estimate sits 13-fold (1.12 log units) below what was measured; the measured number lies above the stated range.
By their numbers in this assay, from the lowest: compound 1; then compounds 2 and 3 (each within the scatter of the next); then compound 4.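

In this assay a methyl group on the aryl ring does not by itself bring the number down, as 4-methylphenyl in place of 2-cyanophenyl gave a 2.2-fold higher number from compound 3 to compound 4 (0.35 log units; beyond the scatter) and 4-methylphenyl in place of 1H-indol-4-yl gave a 3.3-fold higher number from compound 2 to compound 4 (0.51 log units; beyond the scatter) on the same oxygen. The largest gap is to the other alkyl-bearing compound, where 4-methylphenyl in place of 2-ethylphenyl gave a 130-fold higher number from compound 1 to compound 4 (2.12 log units; beyond the scatter) and so carrying an alkyl group does not unite compound 1 and compound 4 in this assay. Nothing measured here explains this difference.

The compounds shown leave open whether the chain or its place on the ring separates 2-ethylphenyl from 4-methylphenyl, since these groups differ in both. 2-Methylphenyl and 4-ethylphenyl would pull those two apart, and 2-propylphenyl would show whether a longer chain is tolerated.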